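A 2-Chloro-4-nitrophenyl Group in Place of 4-Fluorophenyl

The compounds below may be only part of what the source reports. "The series", "measured", "known", "first", "only" and "open" are said of these compounds alone.

In an ADME assay on H9c2 cells (Rattus norvegicus) for cytotoxicity, read by MTT assay, with a stated time of 48 h (on this read-out lower numbers stand for stronger inhibition and higher numbers for weaker inhibition), compound 1 (`CC(C)(Oc1ccc(Cl)cc1)C(=O)NCCOC(=S)Nc1ccc(F)cc1`) gives > 800000 nM as a limit of the assay and not a number. Its place among the results is therefore only a bound (the limit of > 800000 nM in this assay, at which 1 of the 3 values shown sits). Compound 2 (`Cc1cnc(C(=O)Oc2ccc(C(N)=S)cc2)c[n+]1[O-]`) gives 780000 nM and compound 3 (`NC(=S)c1ccc(OC(=O)c2cccnc2)cc1`) gives 754000 nM in this assay and these two values lie within the usual scatter of each other.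

The next compound to be tested is compound 4 (`CC(C)(Oc1ccc(Cl)cc1)C(=O)NCCOC(=S)Nc1ccc([N+](=O)[O-])cc1Cl`), which carries 2-chloro-4-nitrophenyl in place of 4-fluorophenyl on an amide-type nitrogen. For the measured compounds named here, no two measured compounds differ in one place only, so no measured step serves as a guide to this change. In this assay a small shift toward stronger inhibition is expected, of a size close to the usual scatter. Going by the values given here, this cautious expectation rests on the narrow band of the available numbers, with compound 2 at 780000 nM and compound 3 at 754000 nM as the only exact values. The estimated change is an at least 1.4-fold lower number from compound 1 to compound 4 (0.16 log units; that floor lies within the scatter) on this reasoning. In this assay the estimate for compound 4 is 550000 nM with an expected range of 200000 nM to 950000 nM for the measurement.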

Compound 4, half-maximal inhibitory concentration: > 800000 nM
Compound 4: only a limit was reported (the forecaster's own chance of this, stated with the estimate: 35%); middle value at least 1.4-fold (0.16 log units) from the limit.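

Compound 1 and compound 4 are both reported only as limits of the assay, and the step between them cannot be read. Both sit at the same limit: the limit of > 800000 nM in this assay, at which 2 of the 4 values shown sit.

The compounds shown leave open whether 2-chloro-4-nitrophenyl in place of 4-fluorophenyl on an amide-type nitrogen changes this read-out at all.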